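Methoxy on the propyl chain of compound 3

The source may hold more compounds than are shown below. What is called first, only, known or untested is meant among the compounds shown, and "the series" means these compounds.

In a functional assay on A-375 cells (Homo sapiens) for antiproliferative activity (on this read-out higher numbers stand for weaker inhibition and lower numbers for stronger inhibition), compound 3 `CCCO/N=C/c1c(N)ncnc1Oc1ccc2[nH]c(C)cc2c1F` gives 28 nM and holds the lowest number of the three measured compounds. Against it stand compound 1 `CCCCO/N=C/c1c(N)ncnc1Oc1ccc2[nH]c(C)cc2c1F` at 446 nM and compound 2 `Cc1cc2c(F)c(Oc3ncnc(N)c3/C=N/OCCO)ccc2[nH]1` at 372 nM on the same read-out. These two do not separate, since a 1.2-fold lower number from compound 1 to compound 2 (0.08 log units; within the scatter) is a step within the scatter.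

Compound 4 `COCCCO/N=C/c1c(N)ncnc1Oc1ccc2[nH]c(C)cc2c1F` differs from compound 3 by methoxy in place of hydrogen on a saturated chain carbon, three bonds along the chain from an oxygen on an unsaturated carbon with propyl becoming 3-methoxypropyl. For the measured compounds named here, the closest precedent is a 16-fold lower number from compound 1 to compound 3 (1.20 log units; beyond the scatter) and that step falls on the same chain carbon, three bonds along the chain from an oxygen on an unsaturated carbon. Read backwards, it links a substituent on that carbon with the higher number. The second relevant step is a 13-fold lower number from compound 2 to compound 3 (1.12 log units; beyond the scatter) at the neighbouring place on the chain, and it is similar in size. Among these three compounds, both departures from the propyl chain carry higher numbers, and none goes against this. Going by the values given here, no measured compound carries a methoxy on the chain, so the size remains uncertain.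

The expected change is an 8.9-fold higher number from compound 3 to compound 4 (0.95 log units; beyond the scatter) in the direction of weaker inhibition and beyond the scatter. For compound 4 the estimated value is 250 nM within an expected range of 70 nM to 800 nM for now.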

Compound 4, half-maximal inhibitory concentration: 300 nM
Estimate against measurement, compound 4: 1.2-fold (0.08 log units) below; the range from low to high includes it.
By their numbers in this assay, from the lowest: compound 3; then compounds 4, 2 and 1 (each within the scatter of the next).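

Working notes on the propyl chain. In this assay, methoxy in place of hydrogen on the saturated chain carbon, three bonds along the chain from an oxygen on an unsaturated carbon, gives a large step (an 11-fold higher number from compound 3 to compound 4 (1.03 log units; beyond the scatter)), so propyl to 3-methoxypropyl is a third departure from the propyl chain that carries a higher number, and among these four compounds none goes against this. Compound 4 does not separate from the two earlier departures (a 1.2-fold lower number from compound 2 to compound 4 (0.09 log units; within the scatter); a 1.5-fold lower number from compound 1 to compound 4 (0.17 log units; within the scatter)), so the chains of compounds 1, 2 and 4, though they end differently, all sit at one level within the scatter, and only compound 3 stands apart from them. Nothing at hand gives a reason for this pattern.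

On these data alone, whether the low number belongs to propyl alone stays open, since a plain ethyl chain has no value here to set beside compound 3. It is also unknown how an amine or a carboxylic acid on that same chain carbon would read on this assay, or whether a longer chain than 3-methoxypropyl would stay at the same level.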